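The compounds below may be only part of what the source reports. "The series", "measured", "known", "first", "only" and "open" are said of these compounds alone.

Measured in a functional assay on A549 cells (Homo sapiens) for antiproliferative activity, read by MTT assay, with a stated time of 72 h; on this read-out lower numbers stand for stronger inhibition and higher numbers for weaker inhibition:
Compound 1, `COc1cc2ncnc(Nc3cccc(Br)c3)c2cc1OCCCN1CCNCCNCCNCC1`: 14700 nM
Compound 2, `COc1cc2ncnc(Nc3ccc(F)c(Br)c3)c2cc1OCCCN1CCNCCNCCNCC1`: 11800 nM
Compound 3, `COc1cccc(Nc2ncnc3cc(OC)c(OCCCN4CCNCCNCCNCC4)cc23)c1`: > 50000 nM, which is a limit of the assay rather than a number

Going by the values given here, compound 2 stands with one of the only two numbers in this set; the step of a 1.2-fold lower number from compound 1 to compound 2 (0.10 log units; within the scatter), a fluoro in place of hydrogen on an aromatic carbon, keeps it within the scatter of the other. Compound 3 gave only (the limit of > 50000 nM in this assay, at which 1 of the 3 values shown sits). Its methoxy in place of bromo on an aromatic carbon gives the step of an at least 3.4-fold higher number from compound 1 to compound 3 (0.53 log units; beyond the scatter), and the swap of the whole aromatic ring on the nitrogen gives an at least 4.2-fold higher number from compound 2 to compound 3 (0.62 log units; beyond the scatter), both read as at least modest weakenings.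

Compound 4, `COc1cc2ncnc(Nc3ccc(Cl)cc3Cl)c2cc1OCCCN1CCNCCNCCNCC1`, has not been measured. It differs from compound 2 as follows: 2,4-dichlorophenyl in place of 3-bromo-4-fluorophenyl on a nitrogen on an aromatic ring. Among the compounds with values here, the one measured change that removed both halogens from the ring on the nitrogen weakened activity, while the change that added a halogen stayed within the scatter. Compound 4 keeps two halogens on that ring, so the step is expected to be small, a 1.7-fold higher number from compound 2 to compound 4 (0.23 log units; within the scatter). Compound 4 is therefore estimated at 20000 nM, in the range 8000 nM to 50000 nM, with some chance that only a limit is reported.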

Compound 4, half-maximal inhibitory concentration: 23800 nM
Estimate against measurement, compound 4: 1.2-fold (0.08 log units) below, within the range that was stated.
By their numbers in this assay, from the lowest: compounds 2, 1 and 4 (each within the scatter of the next). At a limit, above all of these: compound 3.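

Compound 4 shows that this place, on a nitrogen on an aromatic ring, can take two chlorines instead of bromine and fluorine, with a different substitution pattern, and still stay within the scatter in this assay: the change gives a 2.0-fold higher number from compound 2 to compound 4 (0.30 log units; within the scatter), and the comparison with the 3-bromophenyl ring gives a 1.6-fold higher number from compound 1 to compound 4 (0.21 log units; within the scatter). Across the four compounds, the three rings bearing halogens thus form one group within the scatter, while the 3-methoxyphenyl ring of compound 3 stands apart, with an at least 2.1-fold lower number from compound 3 to compound 4 (0.32 log units; beyond the scatter). The reading for compound 3 is a limit of the assay and not a number: the limit of > 50000 nM in this assay, at which 1 of the 4 values shown sits.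

The compounds shown leave open whether halogens are needed at all, which a plain phenyl ring or a ring carrying methyl or trifluoromethyl would help to test. All four compounds also share the same side chain on the core, so a morpholine or a simple dimethylamine at its end would be needed to show how much of these values depends on that part of the molecule.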